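The source may report more compounds than this note shows. Statements on the series, on what has been measured and on what is new or still open speak of the compounds shown alone.

Working notes on the series. The shared core is seen in compound 1 `O=C(O)COc1ccncc1-c1ccc2ccccc2c1`, for which an assay on a protein complex for inhibition of CDK8/Cyclin C (Homo sapiens), with a stated time of 1 h (on this read-out lower numbers stand for stronger inhibition and higher numbers for weaker inhibition), records "not determined" (no result reported). Compound 2 `CCOC(=O)/C=C/c1ccncc1-c1ccc2ccccc2c1` gives 53.3 nM in this assay, the highest of the two numbers recorded; compound 3 `CNC(=O)CCc1ccncc1-c1ccc2ccccc2c1` gives 21.1 nM. Among the measured compounds shown here, the one measured step, a 2.5-fold lower number from compound 2 to compound 3 (0.40 log units; beyond the scatter), exchanges the ester for a methylamide and saturates the linker at once. Compound 4 `O=C(O)CCNC(=O)/C=C/c1ccncc1-c1ccc2ccccc2c1` differs from compound 2 in one place: (2-carboxyethyl)amino in place of ethoxy on a carbonyl carbon. Only the ester-to-amide part of the measured step bears on this change, so a step of similar or smaller size in the same direction is expected in this assay. For compound 4 the estimate is 30 nM, within 10 nM to 90 nM, which would mean a 1.8-fold lower number from compound 2 to compound 4 (0.25 log units; within the scatter).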

Compound 4, half-maximal inhibitory concentration: 870 nM
Compound 4: the middle estimate sits 29-fold (1.46 log units) below what was measured, outside the stated range (above it).
By their numbers in this assay, from the lowest: compound 3; then compound 2; then compound 4.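

In this assay, among the compounds shown here, (2-carboxyethyl)amino in place of ethoxy on a carbonyl carbon gives a 16-fold higher number from compound 2 to compound 4 (1.21 log units; beyond the scatter) and is the largest step so far. Set against a 2.5-fold lower number from compound 2 to compound 3 (0.40 log units; beyond the scatter), where the linker also changes, this shows that an amide at this carbonyl does not by itself lower the number: what the amide carries counts. Nothing at hand accounts for the size of this step.

From the compounds shown here alone, it remains open whether the carboxylic acid or the chain length carries the step. A methylamide on the same double-bonded chain, or a methyl ester in place of the carboxylic acid, would bear on this.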